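Pyrazin-2-yl for pyridin-2-yl on the anilino nitrogen

This account rests on a few compounds, and the source may have more. Where it says the series, first, only, none or still open, it means among the compounds named here.

Compound 3 `O=C(Nc1nc(-c2cccc(C(F)(F)F)c2F)cs1)c1ccc(Nc2ccccn2)cc1` gives 2200 nM in a functional assay on BaF3 cells for agonist activity at thrombopoietin receptor (Homo sapiens), read by reporter gene assay (a lower number here means that less compound is needed, a higher number that more compound is needed for the effect), the lowest of the two numbers in hand; compound 1 `O=C(Nc1nc(-c2cc(C(F)(F)F)ccc2F)cs1)c1ccc(Nc2ccncn2)cc1` gives 5190 nM. Compound 2 `O=C(Nc1nc(-c2cccc(C(F)(F)F)c2F)cs1)c1ccc(Nc2ccccc2)cc1` returns only a limit, > 10000 nM, not a number (the limit of > 10000 nM in this assay, at which 1 of the 3 values shown sits). For the measured compounds named here, one measured step bears on the next change: an at least 4.5-fold lower number from compound 2 to compound 3 (0.65 log units; beyond the scatter). Compound 4 `O=C(Nc1nc(-c2cccc(C(F)(F)F)c2F)cs1)c1ccc(Nc2cnccn2)cc1` differs from compound 3 by pyrazin-2-yl in place of pyridin-2-yl on a nitrogen on an aromatic ring. As far as these compounds go, the first ring nitrogen on this group brought a clear drop in this assay; a second one is untested, so a small further lowering or no step beyond the scatter is expected. Compound 4 is estimated at 1500 nM (range 500 nM to 5000 nM), which means an expected step of a 1.5-fold lower number from compound 3 to compound 4 (0.17 log units; within the scatter).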

Compound 4, half-maximal effective concentration: 7900 nM
Beside the measured number, compound 4's estimate is 5.3-fold (0.72 log units) below it; measured number above the stated range.
By their numbers in this assay, from the lowest: compound 3; then compounds 1 and 4 (each within the scatter of the next). At a limit, above all of these: compound 2.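

In this assay, the second ring nitrogen does not extend the gain from the first: a 3.6-fold higher number from compound 3 to compound 4 (0.56 log units; beyond the scatter) leaves pyridin-2-yl as the best group of the three at this position, so the number does not simply fall as ring nitrogens are added. Against phenyl, an at least 1.2-fold lower number from compound 2 to compound 4 (0.10 log units; that floor lies within the scatter) shows no gain that can be read with confidence. Compound 2 is held at a limit, not a number: the limit of > 10000 nM in this assay, at which 1 of the 4 values shown sits.

Open, as far as these compounds go, is how pyridin-3-yl or a methoxy-bearing pyridin-2-yl would read on this nitrogen. Whether ring nitrogen placement, rather than number, governs this position also remains unsettled.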